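Extending the amide aryl group in the bis-indole nitrile series

The compounds below may be only part of what the source reports. "The series", "measured", "known", "first", "only" and "open" are said of these compounds alone.

Compound 1 `CN1[C@@H]2c3[nH]c4ccccc4c3C[C@H]1[C@H](C#N)N1[C@@H](CNC(=O)c3ccc(Cl)cc3)c3[nH]c4ccccc4c3C[C@@H]21` carries a 4-chlorophenyl on the amide carbonyl and in a functional assay on BGC-823 cells (Homo sapiens) for cytotoxicity, read by MTT assay, with a stated time of 72 h (a higher number here means a weaker inhibitor, a lower number a stronger inhibitor), compound 1 gives 110 nM, the lowest number among the three measured here. Compound 2 `COc1ccc(C(=O)NC[C@H]2c3[nH]c4ccccc4c3C[C@H]3[C@H]4c5[nH]c6ccccc6c5C[C@@H]([C@H](C#N)N23)N4C)cc1` gives 320 nM in this assay, and compound 3 `CN1[C@@H]2c3[nH]c4ccccc4c3C[C@H]1[C@H](C#N)N1[C@@H](CNC(=O)/C=C/c3ccccc3)c3[nH]c4ccccc4c3C[C@@H]21` gives 4300 nM. The two steps away from compound 1 both weaken inhibition: a 2.9-fold higher number from compound 1 to compound 2 (0.46 log units; beyond the scatter), and a 39-fold higher number from compound 1 to compound 3 (1.59 log units; beyond the scatter). The same inserted ethenyl, read against the methoxy analogue, gives a 13-fold higher number from compound 2 to compound 3 (1.13 log units; beyond the scatter).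

Compound 4 `COc1ccc(/C=C/C(=O)NC[C@H]2c3[nH]c4ccccc4c3C[C@H]3[C@H]4c5[nH]c6ccccc6c5C[C@@H]([C@H](C#N)N23)N4C)cc1` combines both changes: 2-(4-methoxyphenyl)ethenyl in place of 4-chlorophenyl on a carbonyl carbon. Both measured steps bear on it. The inserted ethenyl costs far more than the methoxy swap, and the two effects, taken together, point to a large loss in this assay. Compound 4 is therefore expected to show a 91-fold higher number from compound 1 to compound 4 (1.96 log units; beyond the scatter), placing it well beyond compound 3 because of a 39-fold higher number from compound 1 to compound 3 (1.59 log units; beyond the scatter) compounded with a 2.9-fold higher number from compound 1 to compound 2 (0.46 log units; beyond the scatter). The estimate for compound 4 in this assay is 10000 nM, with a range from 3000 nM to 35000 nM.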

Compound 4, half-maximal inhibitory concentration: 5450 nM
For compound 4 the middle estimate is 1.8-fold (0.26 log units) above the measured one; the range from low to high includes it.
By their numbers in this assay, from the lowest: compound 1; then compound 2; then compounds 3 and 4 (each within the scatter of the next).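

With the ethenyl in place, the added methoxy leaves this assay unchanged within the scatter, at a 1.3-fold higher number from compound 3 to compound 4 (0.10 log units; within the scatter), whereas the methoxy swap on the directly attached phenyl gave a 2.9-fold higher number from compound 1 to compound 2 (0.46 log units; beyond the scatter). Both directly attached aryl amides lie far from the 2-(4-methoxyphenyl)ethenyl amide, with a 50-fold higher number from compound 1 to compound 4 (1.70 log units; beyond the scatter) and a 17-fold higher number from compound 2 to compound 4 (1.23 log units; beyond the scatter), so across these four compounds the large steps go with the ethenyl-containing groups on the carbonyl carbon, and the methoxy adds no readable loss to that of the ethenyl. No supporting data explain this loss.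

From the compounds shown here alone, it remains open whether a saturated two-carbon chain in place of the ethenyl would recover the lower numbers of compound 1 and compound 2. Going by these compounds, it is equally open whether an amine or a carboxylic acid on the phenyl ring would separate itself from compound 3 and compound 4.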